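The compounds below may be only part of what the source reports. "The series", "measured", "known", "first", "only" and "open" are said of these compounds alone.

Measured in a functional assay for inhibition, with Rattus norvegicus as the target; on this read-out higher numbers stand for weaker inhibition and lower numbers for stronger inhibition:
- compound 1 `CC(C)(C)/N=c1\c(O)c(O)\c1=N/Cc1ccccc1`: 3400 nM
- compound 2 `CC(C)(C)/N=c1\c(O)c(O)\c1=N/Cc1ccc(Cl)cc1`: 1700 nM

Within the data shown here, compound 1 stands within the scatter of compound 2, the only other measured compound, so the two cannot be ordered. The next compound, compound 3 `CC(C)(C)/N=c1\c(O)c(O)\c1=N/Cc1ccccn1`, differs from compound 1 as follows: pyridin-2-yl in place of phenyl on a saturated chain carbon bound to a double-bonded nitrogen. In short, pyridin-2-yl replaces phenyl on a saturated chain carbon bound to a double-bonded nitrogen.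

Among the measured compounds shown here, only one measured step bears on this, and only indirectly. It is a 2.0-fold lower number from compound 1 to compound 2 (0.30 log units; within the scatter), with chloro in place of hydrogen on an aromatic carbon, and it stays within the scatter. For the measured compounds named here, no measured step exchanges the ring itself, so guidance is thin. In this assay, no step beyond the scatter is expected, with a slight and unsupported lean towards a higher number. The estimate amounts to an expected 1.3-fold higher number from compound 1 to compound 3 (0.12 log units; within the scatter). For compound 3 the estimated value is 4500 nM, with an expected range of 1500 nM to 13000 nM.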

Compound 3, half-maximal inhibitory concentration: 11500 nM
Beside the measured number, compound 3's estimate is 2.6-fold (0.41 log units) below it; measured number inside the range.
By their numbers in this assay, from the lowest: compounds 2 and 1 (each within the scatter of the next); then compound 3.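

The ring on the saturated chain carbon bound to a double-bonded nitrogen matters in this assay: pyridin-2-yl in place of phenyl gives a 3.4-fold higher number from compound 1 to compound 3 (0.53 log units; beyond the scatter), the only step shown that lies beyond the scatter, and the size of the step is modest. The change swaps a ring of carbon only for a ring holding a hetero atom and a hydrogen-bond acceptor, and on this single pair it goes with weaker inhibition. Nothing available explains the direction of this step.

Pyridin-3-yl or pyridin-4-yl at this place would show whether the result depends on where the ring nitrogen sits or merely on its presence. Going by these compounds, it also remains open whether an amine or a carboxylic acid on the phenyl ring would move the number beyond the scatter in either direction.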